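Bromo for methoxy on the benzyl group of compound 1

A few compounds are considered here, and "the series" means these few. Any claim that something is new, unique, unknown or untested is made for them only; others in the source may bear on it.

Compound 1 `CCOC(=O)/C=C/c1ccc2c(c1)C(=O)C(=O)N2Cc1ccc(OC)cc1` gives 90 nM
Compound 2 `CCCCOC(=O)/C=C/c1ccc2c(c1)C(=O)C(=O)N2Cc1ccc(OC)cc1` gives 630 nM
Compound 3 `COc1ccc(CN2C(=O)C(=O)c3cc(/C=C/C(=O)N4CCCC4)ccc32)cc1` gives 7810 nM

In a functional assay on HepG2 cells (Homo sapiens) for cytotoxicity, read by MTT assay, with a stated time of 48 h (on this read-out lower numbers stand for stronger inhibition and higher numbers for weaker inhibition), compound 1 holds the lowest of the three numbers, and both other compounds lie beyond the scatter from it. Compound 4 `CCOC(=O)/C=C/c1ccc2c(c1)C(=O)C(=O)N2Cc1ccc(Br)cc1` keeps the core of compound 1 and changes the 4-methoxybenzyl group to 4-bromobenzyl, with bromo in place of methoxy on an aromatic carbon, para to a large group: bromo in place of methoxy on an aromatic carbon.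

Among the compounds with values here, no measured compound varies this group, so no step speaks to the change directly. The three measured steps all lie at the carbonyl end of the molecule: a 7.0-fold higher number from compound 1 to compound 2 (0.85 log units; beyond the scatter), an 87-fold higher number from compound 1 to compound 3 (1.94 log units; beyond the scatter) and a 12-fold higher number from compound 2 to compound 3 (1.09 log units; beyond the scatter). They show only that this assay can respond strongly to a change elsewhere in the series, so they give a loose guide to size and none to direction. Within the data shown here, since compound 1 at 90 nM is the lowest number so far, a rise is expected to be somewhat more likely than a fall. The expected change is modest, estimated as a 2.2-fold higher number from compound 1 to compound 4 (0.35 log units; beyond the scatter), with a wide margin. Compound 4 is estimated at 200 nM, within an expected range of 50 nM to 900 nM.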

Compound 4, half-maximal inhibitory concentration: 290 nM
Estimate against measurement, compound 4: 1.5-fold (0.16 log units) below; low and high end bracket the measured number.
By their numbers in this assay, from the lowest: compound 1; then compound 4; then compound 2; then compound 3.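

The benzyl end of the molecule also responds in this assay: with the ethyl ester and the shared core held constant, the change from 4-methoxybenzyl to 4-bromobenzyl gives a 3.2-fold higher number from compound 1 to compound 4 (0.51 log units; beyond the scatter). Within the data shown here, this is the first measured change away from the carbonyl end, and it is modest, like a 7.0-fold higher number from compound 1 to compound 2 (0.85 log units; beyond the scatter), whereas an 87-fold higher number from compound 1 to compound 3 (1.94 log units; beyond the scatter) is large, so this position is sensitive to substitution but this particular swap leaves compound 4 at 290 nM. No measurement available here accounts for the higher number with bromo in place of methoxy.

A single pair cannot separate the loss of methoxy from the gain of bromo, and that question would need comparison with the same position carrying hydrogen, fluoro, chloro or an amine. From the compounds shown here alone, it also remains open whether the step from methoxy to bromo would carry over to the compounds with butoxy or pyrrolidin-1-yl on the carbonyl carbon, or whether its size depends on the ethoxy group kept in compound 1 and compound 4.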